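The compounds below may be only part of what the source reports. "The series", "measured", "known", "first", "only" and "open" are said of these compounds alone.

Compound 1 `CN(Cc1ccc(-c2ccccc2)cc1)Cc1cn(C)c2ccc(CNc3ccc(F)cc3)cc12` was tested in a functional assay on HeLa cells (Homo sapiens) for antiproliferative activity, read by MTT assay, with a stated time of 72 h (a higher number here means a weaker inhibitor, a lower number a stronger inhibitor), where compound 1 gives 8180 nM. Compound 2 `CN(Cc1ccc(-c2ccccc2)cc1)Cc1cn(C)c2ccc(C(=O)Nc3ccc(F)cc3)cc12` differs from it in one place, and in this assay compound 2 gives 23600 nM. That change produced a 2.9-fold higher number from compound 1 to compound 2 (0.46 log units; beyond the scatter). Among the two measured numbers, compound 2 holds the highest, with compound 1 as its only neighbour.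

Compound 3 `COc1cc(CN(C)Cc2cn(C)c3ccc(C(=O)Nc4ccc(F)cc4)cc23)cc(OC)c1OC` has not yet been measured. It keeps the amide of compound 2 and changes a different part: 3,4,5-trimethoxyphenyl in place of 4-phenylphenyl on a saturated chain carbon bound to an amine nitrogen. Among the measured compounds shown here, the only measured step, from compound 1 to compound 2, concerns the link between the core and the fluorophenyl group and says nothing about the group carried on the amine. For the measured compounds named here, no measured step therefore bears on this change, and there is no basis in these numbers for expecting a shift in either direction beyond the scatter. The expected step in this assay is a 1.2-fold lower number from compound 2 to compound 3 (0.07 log units; within the scatter), with wide uncertainty. Compound 3 is therefore estimated at 20000 nM, with a range from 5000 nM to 80000 nM.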

Compound 3, half-maximal inhibitory concentration: 4210 nM
Beside the measured number, compound 3's estimate is 4.8-fold (0.68 log units) above it; measured number outside the range, below it.
By their numbers in this assay, from the lowest: compounds 3 and 1 (each within the scatter of the next); then compound 2.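

In this assay, the group carried on the amine clearly affects the result: swapping the 4-phenylphenyl group for 3,4,5-trimethoxyphenyl on a saturated chain carbon bound to an amine nitrogen gives a 5.6-fold lower number from compound 2 to compound 3 (0.75 log units; beyond the scatter). Among the compounds shown here, the earlier pair varied only the link to the fluorophenyl group, so this is the first sign that this other position also moves the number. Both groups hold 12 heavy atoms, but the entering group has one six-membered aromatic ring and 3 hydrogen-bond acceptors, while the leaving group has 2 such rings and 0 acceptors, and no independent measurement shows why the number falls.

A plain phenyl or a 4-methoxyphenyl group on the same carbon would help show whether the step follows the loss of the second ring or the arrival of the methoxy groups. On these data alone, it also remains open whether 3,4,5-trimethoxyphenyl would lower the number in the same way when paired with the ((4-fluorophenyl)amino)methyl group of compound 1 rather than the amide of compound 2.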